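The source may report more compounds than this note shows. Statements on the series, on what has been measured and on what is new or still open speak of the compounds shown alone.

Compound 1, with the structure `CN(c1cccc2c1CN(c1nc(Nc3ccc(Cl)c(C(F)(F)F)c3)ncc1C(F)(F)F)C2)S(C)(=O)=O`, is one of three compounds tested in a functional assay on HepG2 cells (Homo sapiens) for antiproliferative activity, read by spectrophotometry, with a stated time of 2 days; a lower number here means a stronger inhibitor of growth, a higher number a weaker inhibitor of growth. In that assay compound 1 gives 16000 nM, the second highest number of the three. Closest to it is compound 3, whose structure is `CN(c1cccc2c1CN(c1nc(Nc3cccc(Oc4ccccc4)c3)ncc1C(F)(F)F)C2)S(C)(=O)=O` and which gives 23000 nM; the two numbers lie within the usual scatter of each other, so no order between them can be claimed. Furthest away is compound 2, with the structure `COc1cc(N2CCN(C(C)=O)CC2)ccc1Nc1ncc(C(F)(F)F)c(N2Cc3cccc(N(C)S(C)(=O)=O)c3C2)n1`, which gives 3800 nM, a number beyond the scatter below that of compound 1.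

Compound 4, with the structure `Cc1ccc(Nc2ncc(C(F)(F)F)c(N3Cc4cccc(N(C)S(C)(=O)=O)c4C3)n2)cc1C`, has not yet been measured. It differs from compound 1 in one place: 3,4-dimethylphenyl in place of 4-chloro-3-(trifluoromethyl)phenyl on a nitrogen on an aromatic ring. The entering group sits on a nitrogen on an aromatic ring whose other neighbours are aromatic carbon. Within the data shown here, no measured pair shows this same change, so its effect can only be guessed. Compound 4 is expected to give a number near that of compound 1, and the step from compound 1 to compound 4 is expected to be about a 1.3-fold higher number from compound 1 to compound 4 (0.10 log units; within the scatter), hardly beyond the scatter. The estimate for compound 4 is therefore 20000 nM, with a range from 8000 nM to 50000 nM.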

Compound 4, concentration for 50% growth inhibition: > 30000 nM
Compound 4: only a limit was reported; the forecaster's own chance of this, stated with the estimate: 20%; middle value at least 1.5-fold (0.17 log units) from the limit.
By their numbers in this assay, from the lowest: compound 2; then compounds 1 and 3 (each within the scatter of the next). At a limit, above all of these: compound 4.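

Among these compounds, this is the first comparison in the set between two compounds that differ in only one place, the aryl group on a nitrogen on an aromatic ring, with the rest of the core of compound 1 unchanged. In this assay, compound 4 carries 3,4-dimethylphenyl and is reported only as a limit, > 30000 nM. Replacing 4-chloro-3-(trifluoromethyl)phenyl gives an at least 1.8-fold higher number from compound 1 to compound 4 (0.27 log units; that floor lies within the scatter), so this one comparison cannot establish a real loss of growth inhibition, and its size rests on a limit of the assay rather than a measured number: the limit of > 30000 nM in this assay, at which 1 of the 4 values shown sits.

It remains open whether the chlorine or the trifluoromethyl group matters more, since 4-chlorophenyl and 3-(trifluoromethyl)phenyl are not among the compounds shown. Also open, as far as these compounds go, is how a phenyl ring bearing a carboxylic acid or an amine would read at this place in this assay.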